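Benzyl for phenyl on the amide nitrogen: working notes

The source may report more compounds than this note shows. Statements on the series, on what has been measured and on what is new or still open speak of the compounds shown alone.

Measured so far:
compound 1 `C=CC1=C(C(=O)Nc2ccccc2)C(c2ccc(Cl)c(Cl)c2)OC1` — > 100000 nM
compound 2 `C=CC1=C(C(=O)Nc2ccccc2OC)C(c2ccc(F)cc2)OC1` — > 100000 nM

Two compounds of the series have been run in a functional assay on HeLa cells (Homo sapiens) for cytotoxicity, read by MTT assay, with a stated time of 24 h; on this read-out lower numbers stand for stronger inhibition and higher numbers for weaker inhibition. Compound 1 gives only a limit of the assay, > 100000 nM. Compound 2 likewise gives only a limit, > 100000 nM. Going by the values given here, both values therefore sit at the limit of > 100000 nM in this assay, at which 2 of the 2 values shown sit, and compound 1 stands at that limit beside the one other value shown; no step between measured compounds can be computed, so the evidence is two limits and nothing more.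

Compound 3 `C=CC1=C(C(=O)NCc2ccccc2)C(c2ccc(Cl)c(Cl)c2)OC1` is not yet measured. It differs from compound 1 by benzyl in place of phenyl on an amide-type nitrogen, a change on an amide-type nitrogen whose other neighbour is the carbonyl carbon, read one bond further out as anilino to benzylamino. Among the compounds with values here, with no measured step to lean on, the expectation in this assay rests on the two limits alone: the step is expected to be a number no higher from compound 1 to compound 3 (the limit leaves the size open), none beyond the scatter. Compound 3 is thus estimated at 100000 nM, with a range from 30000 nM to 300000 nM, and most probably again only a limit.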

Compound 3, half-maximal inhibitory concentration: > 100000 nM
Compound 3: no number, only a limit; the forecaster's own chance of this, stated with the estimate: 80%; the middle value lies on the limit itself.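

In this assay compound 3 gives > 100000 nM as a limit of the assay and not a number. Going by these compounds alone, compound 1 is also only a limit, and no step between compound 1 and compound 3 can be read. The compounds shown leave open whether benzyl in place of phenyl on the amide-type nitrogen changes the read-out at all.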